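The source may hold more compounds than are shown below. What is called first, only, known or untested is meant among the compounds shown, and "the series" means these compounds.

Measured so far in a functional assay on CWR22R cells (Homo sapiens) for antiproliferative activity, read by propidium iodide staining, with a stated time of 96 h; a higher number here means a weaker inhibitor, a lower number a stronger inhibitor: compound 1 `CC(O)(CS(=O)(=O)c1ccccc1C(F)(F)F)C(=O)Nc1ccc(S(F)(F)(F)(F)F)cc1` gives 17400 nM; compound 2 `CC(O)(CS(=O)(=O)c1ccc(OC(F)(F)F)cc1)C(=O)Nc1ccc(S(F)(F)(F)(F)F)cc1` gives 51900 nM; compound 3 `CC(O)(CS(=O)(=O)c1ccccc1C(F)(F)F)C(=O)Nc1cccc(S(F)(F)(F)(F)F)c1` gives 27700 nM.

Compound 1 and compound 2 differ in one place, (4-(trifluoromethoxy)phenyl in place of 2-(trifluoromethyl)phenyl on a sulfonyl sulfur). That single change produced a 3.0-fold higher number from compound 1 to compound 2 (0.47 log units; beyond the scatter). Compound 3 shares all its atoms with compound 1, joined differently; the difference between the two cores is not broken down here. The values of compound 3 and compound 1 lie within the usual scatter of each other. Compound 4 `CC(O)(CS(=O)(=O)c1ccc(OC(F)(F)F)cc1)C(=O)Nc1cccc(S(F)(F)(F)(F)F)c1`, not yet measured, carries the same change on the core of compound 3: 4-(trifluoromethoxy)phenyl in place of 2-(trifluoromethyl)phenyl on a sulfonyl sulfur. For compound 4 a step of about a 2.9-fold higher number from compound 3 to compound 4 (0.46 log units; beyond the scatter) is expected in this assay, set beside the earlier step because that is what a 3.0-fold higher number from compound 1 to compound 2 (0.47 log units; beyond the scatter) showed, though a single pair is a thin basis. Compound 4 is thus estimated at 80000 nM, likely between 30000 nM and 200000 nM.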

Compound 4, half-maximal inhibitory concentration: 31200 nM
Compound 4: middle estimate off by 2.6-fold (0.41 log units), on the high side; low and high end bracket the measured number.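

Putting 4-(trifluoromethoxy)phenyl in place of 2-(trifluoromethyl)phenyl on the sulfonyl sulfur gives a 1.1-fold higher number from compound 3 to compound 4 (0.05 log units; within the scatter) in this assay, a step that cannot be told from no change at all. Even so, this step cannot be separated from the earlier one on the core of compound 1: the same change on two cores in this assay, a 3.0-fold higher number (0.47 log units; beyond the scatter) from compound 1 to compound 2 and a 1.1-fold higher number (0.05 log units; within the scatter) from compound 3 to compound 4, 2.6-fold (0.42 log units) apart, within the scatter of two such steps. The two pairs therefore do not show that the core alters the effect of this change, nor do they prove that the change carries over unaltered, since two steps are a thin basis for either claim.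

The compounds shown leave open how this change would behave on a third core. They also leave open what an amine or a carboxylic acid on the phenyl ring would do on either core.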